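Removing the Acetyl Group from a Weak Sulfanyl Analogue

The source may hold more compounds than are shown below. What is called first, only, known or untested is meant among the compounds shown, and "the series" means these compounds.

Compound 1 `CC(=O)OC(C)n1cnc2c(Cl)nc(F)nc21` and compound 2 `CC(=O)OC(C)n1cnc2c(S)nc(F)nc21` share one core; compound 2 carries sulfanyl where compound 1 carries chloro. In a functional assay on CCRF-CEM cells (Homo sapiens) for inhibition (on this read-out higher numbers stand for weaker inhibition and lower numbers for stronger inhibition), compound 1 gives 44000 nM. For compound 2 the reading in this assay is only a limit, > 500000 nM. For the measured compounds named here, the single measured step, an at least 11-fold higher number from compound 1 to compound 2 (1.05 log units; beyond the scatter), rests on (the limit of > 500000 nM in this assay, at which 1 of the 2 values shown sits). Compound 3 `CC(O)n1cnc2c(S)nc(F)nc21` differs from compound 2 by hydrogen in place of acetyl on an oxygen on a saturated carbon. Going by the values given here, no measured step touches this position, so no direct guide exists. With compound 2 already at the limit, compound 3 is expected to stay weak, a step that the limit leaves unreadable from compound 2 to compound 3. The estimate for compound 3 is 700000 nM, between 250000 nM and 3000000 nM.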

Compound 3, half-maximal inhibitory concentration: > 500000 nM
Compound 3: no number, only a limit; the forecaster's own chance of this, stated with the estimate: 75%; the middle value does not contradict the limit.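

Compound 2 and compound 3 both stop at a limit in this assay, so no step between them can be read: the limit of > 500000 nM in this assay, at which 2 of the 3 values shown sit.

The compounds shown leave open whether hydrogen in place of acetyl changes inhibition at all.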